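The source may report more compounds than this note shows. Statements on the series, on what has been measured and on what is new or still open speak of the compounds shown alone.

Measured so far:
Compound 1 `O=C(C1CC1)N1CCN(Cc2nc3ccccc3n2Cc2ccccc2C(F)(F)F)CC1`: 56.3%
Compound 2 `Cc1ccc(C(=O)N2CCN(Cc3nc4ccccc4n3Cc3cccc(C)c3)CC2)cc1`: 64.9%
Compound 3 `Cc1cccc(Cn2c(CN3CCN(C(=O)C(C)C)CC3)nc3ccccc32)c1`: 87.2%

In an assay on isolated protein for inhibition of aldehyde dehydrogenase 1A1 (Homo sapiens), read by spectrophotometry, tested at 10 uM (on this read-out lower numbers stand for less inhibition and higher numbers for more inhibition at the one concentration tested (going by the name of the read-out)), compound 1 gives the lowest of the three numbers; compound 2 lies within the scatter of it, while compound 3 lies beyond it. Going by the values given here, the one single-place step seen so far, a number 22.3 percentage points higher from compound 2 to compound 3 (beyond the scatter), changes the group on the carbonyl carbon and does not touch the part altered here. Compound 4 `CCCCn1c(CN2CCN(C(=O)C3CC3)CC2)nc2ccccc21` differs from compound 1 in one place: propyl in place of 2-(trifluoromethyl)phenyl on a saturated chain carbon bound to an aromatic nitrogen. Among the compounds with values here, no measured step bears on this change, so the expectation rests on compound 1 alone and is wide. A moderate drop in inhibition is expected, a number 11.3 percentage points lower from compound 1 to compound 4 (beyond the scatter), and compound 4 is estimated at 45%, between 20% and 70%.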

Compound 4, a percentage reported as inhibition, at one concentration (the size of the read-out at that concentration, not a potency): 18.2%
Compound 4: middle estimate off by 26.8 percentage points, on the high side; measured number below the stated range.
By their numbers in this assay, from the lowest: compound 4; then compounds 1 and 2 (each within the scatter of the next); then compound 3.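

In this assay, the group on a saturated chain carbon bound to an aromatic nitrogen clearly matters: propyl in place of 2-(trifluoromethyl)phenyl gives a number 38.1 percentage points lower from compound 1 to compound 4 (beyond the scatter), a large step. Going by these compounds alone, the earlier step changed only the group on the carbonyl carbon, so this is the first sign that this second place also moves the read-out. No available data explain the size of this drop.

The compounds shown do not separate the loss of the ring from the loss of the trifluoromethyl group. As far as these compounds go, how a plain phenyl or a longer chain such as hexyl would read at this place remains open.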